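A Second Bromo on Already Weak Inhibitors

A few compounds are considered here, and "the series" means these few. Any claim that something is new, unique, unknown or untested is made for them only; others in the source may bear on it.

Compound 1 `COc1cc(/C=N/Nc2nc(-c3ccc(C(F)(F)F)cc3)cs2)c(Br)c(Br)c1OC` — > 100000 nM
Compound 2 `COc1cc(/C=N/Nc2nc(-c3cc(C(F)(F)F)cc(C(F)(F)F)c3)cs2)cc(Br)c1OC` — > 100000 nM
Compound 3 `COc1cc(/C=N/Nc2nc(-c3ccc(C(F)(F)F)cc3)cs2)cc(Br)c1OC` — 41000 nM

In a functional assay on U-87MG ATCC cells for inhibition, with U-87 MG (Homo sapiens) as the target, read by MTT assay, with a stated time of 48 h (a higher number here means a weaker inhibitor, a lower number a stronger inhibitor), compound 3 gives 41000 nM. For compound 1 this assay reports only a limit, > 100000 nM. The change between them is bromo in place of hydrogen on an aromatic carbon, and it gave an at least 2.4-fold higher number from compound 3 to compound 1 (0.38 log units; beyond the scatter); the step can only be stated as a minimum because the limit of > 100000 nM in this assay, at which 2 of the 3 values shown sit, caps what the assay reports.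

For compound 2 this assay likewise reports only a limit, > 100000 nM. The difference between the cores of compound 2 and compound 3 is not broken down here.

Compound 4 `COc1cc(/C=N/Nc2nc(-c3cc(C(F)(F)F)cc(C(F)(F)F)c3)cs2)c(Br)c(Br)c1OC` is not yet measured. It differs from compound 2 by bromo in place of hydrogen on an aromatic carbon, the same change as from compound 3 to compound 1, at the same kind of place. Because an at least 2.4-fold higher number from compound 3 to compound 1 (0.38 log units; beyond the scatter) moved a weak number to the limit, and compound 2 already sits at that limit, the step in this assay is expected to be a step that the limit leaves unreadable from compound 2 to compound 4. For compound 4 the expected value is 200000 nM, between 100000 nM and 1000000 nM, most likely reported again only as a limit.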

Compound 4, half-maximal inhibitory concentration: > 100000 nM
Compound 4: only a limit was reported; the forecaster's own chance of this, stated with the estimate: 90%; the middle value lies beyond the limit too.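

In this assay compound 4 gives > 100000 nM, which is a limit and not a number. Compound 2 also stands at a limit, so no step from one to the other can be read: the limit of > 100000 nM in this assay, at which 3 of the 4 values shown sit.

The compounds shown leave open how strongly compound 2 and compound 4 really inhibit, and whether the added bromo changes anything between them.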